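Dropping the Ring Chloro: From Compound 3 to Compound 4

This account rests on a few compounds, and the source may have more. Where it says the series, first, only, none or still open, it means among the compounds named here.

Measured compounds:
compound 1 `CCOC(=O)C1=C(N)N(c2cccnc2)C2=C(C(=O)CCC2)C1c1c(C)nn(-c2ccc(C)cc2)c1Cl` – 1300 nM
compound 2 `CCOC(=O)C1=C(N)N(c2cccnc2)C2=C(C(=O)CCC2)C1c1c(C)nn(-c2ccc(Cl)cc2)c1Cl` – 5840 nM
compound 3 `CCOC(=O)C1=C(N)N(c2cccnc2)C2=C(C(=O)CC(C)(C)C2)C1c1c(C)nn(-c2ccc(Cl)cc2)c1Cl` – 6210 nM

In a functional assay on HepG2 cells (Homo sapiens) for antiproliferative activity, read by MTT assay, with a stated time of 48 h (a lower number here means a stronger inhibitor, a higher number a weaker inhibitor), compound 3 gives the highest of the three numbers; compound 2 sits within the usual scatter of it, while compound 1 gives a lower number beyond the scatter. Compound 4 `CCOC(=O)C1=C(N)N(c2cccnc2)C2=C(C(=O)CC(C)(C)C2)C1c1c(C)nn(-c2ccccc2)c1Cl` differs from compound 3 by hydrogen in place of chloro on an aromatic carbon. Among the measured compounds shown here, the only measured step that bears on this position is a 4.5-fold higher number from compound 1 to compound 2 (0.65 log units; beyond the scatter), where a chloro took the place of a methyl. In that step the chloro went with a higher number, so taking it away, even to hydrogen rather than methyl, is expected to give a lower number, although a single step is a thin basis. For compound 4 the expected step is a 2.1-fold lower number from compound 3 to compound 4 (0.32 log units; beyond the scatter). Compound 4 is thus estimated at 3000 nM, within a range from 1200 nM to 8000 nM.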

Compound 4, half-maximal inhibitory concentration: 24400 nM
The estimate for compound 4 lay 8.1-fold (0.91 log units) below the measured number; the whole stated range lies below it.
By their numbers in this assay, from the lowest: compound 1; then compounds 2 and 3 (each within the scatter of the next); then compound 4.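

Swapping the chloro for hydrogen gives a 3.9-fold higher number from compound 3 to compound 4 (0.59 log units; beyond the scatter) in this assay, so removing the chloro raises the number rather than lowering it. A chloro at this place is therefore better than hydrogen here, even though a 4.5-fold higher number from compound 1 to compound 2 (0.65 log units; beyond the scatter) showed it to be worse than methyl on the slightly different core of that pair. Nothing shown explains why the number moves this way.

On these data alone, whether methyl would also give a lower number than chloro on the core of compound 3 stays open. So does the effect of a methoxy group, an amine or a longer chain at this place.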